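This account rests on a few compounds, and the source may have more. Where it says the series, first, only, none or still open, it means among the compounds named here.

Measured so far:
- Compound 1, `COc1cc(/C=C/C(=O)c2cccc(-n3cc(-c4ccc(Cl)cc4)[nH]c3=O)c2)cc(OC)c1OC`: 3220 nM
- Compound 2, `COc1cc(/C=C/C(=O)c2cccc(-n3cc(-c4ccccc4)[nH]c3=O)c2)cc(OC)c1OC`: 1710 nM
- Compound 3, `COc1ccc(-c2cn(-c3cccc(C(=O)/C=C/c4ccc(O)c(OC)c4)c3)c(=O)[nH]2)cc1`: 5850 nM

All three were tested in a functional assay on RXF 393 cells (Homo sapiens) for inhibition; on this read-out lower numbers stand for stronger inhibition of growth and higher numbers for weaker inhibition of growth. Compound 3 and compound 1 lie within the scatter of each other, so nothing separates them; compound 2, with the lower number, lies beyond the scatter from compound 3.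

The compound under consideration is compound 4, `COc1ccc(-c2cn(-c3cccc(C(=O)/C=C/c4cc(OC)c(OC)c(OC)c4)c3)c(=O)[nH]2)cc1`. It differs from compound 3 in one place: 3,4,5-trimethoxyphenyl in place of 4-hydroxy-3-methoxyphenyl on a double-bonded chain carbon bound to a double-bonded chain carbon. With this change compound 4 carries the same chain-bound aryl group as compound 1 and compound 2, while keeping the 4-methoxyphenyl of compound 3 on the shared core.

Going by the values given here, the only measured step between neighbours, a 1.9-fold lower number from compound 1 to compound 2 (0.27 log units; within the scatter), concerns a different position and does not bear on this change. What remains is the plain observation that the two trimethoxyphenyl compounds, compound 1 and compound 2, give lower numbers than compound 3, one within and one beyond the scatter. On that basis compound 4 is expected to move toward the values of compound 1 and compound 2, giving a 2.3-fold lower number from compound 3 to compound 4 (0.37 log units; beyond the scatter) in this assay. The estimate for compound 4 is 2500 nM, with a range from 1000 nM to 6000 nM.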

Compound 4, concentration for 50% growth inhibition: 1920 nM
Compound 4: the middle estimate sits 1.3-fold (0.11 log units) above what was measured; low and high end bracket the measured number.
By their numbers in this assay, from the lowest: compounds 2, 4, 1 and 3 (each within the scatter of the next, the first and the last beyond it).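

In this assay, going by these compounds alone, exchanging 4-hydroxy-3-methoxyphenyl for 3,4,5-trimethoxyphenyl on the double-bonded chain carbon gives a step beyond the scatter (a 3.0-fold lower number from compound 3 to compound 4 (0.48 log units; beyond the scatter)), and the earlier compounds offered no pair that isolated this change. With 3,4,5-trimethoxyphenyl in place, the other aromatic position shows no separable effect: both methoxy in place of hydrogen (a 1.1-fold higher number from compound 2 to compound 4 (0.05 log units; within the scatter)) and methoxy in place of chloro (a 1.7-fold lower number from compound 1 to compound 4 (0.22 log units; within the scatter)) stay within the scatter, so hydrogen, chloro and methoxy cannot be told apart there on this read-out. No measurement shown here explains why the chain-bound aryl exchange changes the number.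

The exchange alters more than one substituent on that ring in a single step, so these compounds cannot say whether losing the hydroxy or gaining the methoxy groups accounts for the step. Also open, going by these compounds, is how an amine or a carboxylic acid on that ring would behave, and whether the same exchange gives a similar step when hydrogen or chloro replaces the methoxy on the other aromatic ring.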